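The compounds below may be only part of what the source reports. "The series", "measured", "known", "first", "only" and "open" are said of these compounds alone.

Measured compounds and their readings:
- compound 1 `Cc1cccc(Cn2c(CN3CCN(C(=O)c4cccnc4)CC3)nc3ccccc32)c1`: 24.5%
- compound 2 `Cc1cccc(Cn2c(CN3CCN(C(=O)C4CCCC4)CC3)nc3ccccc32)c1`: 67.5%
- compound 3 `Cc1cccc(Cn2c(CN3CCN(C(=O)c4ccc(C(C)C)cc4)CC3)nc3ccccc32)c1`: 67.6%

All three were tested in an assay on isolated protein for inhibition of aldehyde dehydrogenase 1A1 (Homo sapiens), read by spectrophotometry, tested at 10 uM; on this read-out lower numbers stand for less inhibition and higher numbers for more inhibition at the one concentration tested (going by the name of the read-out). Compound 3 stands at the highest of the three numbers, but its gap to compound 2, a number 0.1 percentage points higher from compound 2 to compound 3 (within the scatter), lies within the scatter, so these two cannot be told apart; only its gap to compound 1, a number 43.1 percentage points higher from compound 1 to compound 3 (beyond the scatter), is beyond the scatter.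

Compound 4 `Cc1cccc(Cn2c(CN3CCN(C(=O)c4ccncc4)CC3)nc3ccccc32)c1` differs from compound 3 in a single place: pyridin-4-yl in place of 4-isopropylphenyl on a carbonyl carbon. The measured step that bears most on this is the one in the opposite direction, a number 43.1 percentage points higher from compound 1 to compound 3 (beyond the scatter), where a pyridin-3-yl gave way to a 4-isopropylphenyl and the inhibition climbed strongly; the step of a number 43 percentage points higher from compound 1 to compound 2 (beyond the scatter) shows a rise of the same size when cyclopentyl replaced that pyridin-3-yl. Going by the values given here, no measured compound carries a pyridin-4-yl, so the comparison rests on a related but not identical ring. A large fall in this assay is therefore expected for compound 4, roughly back toward the reading of compound 1, 24.5%. The expected step is a number 39.6 percentage points lower from compound 3 to compound 4 (beyond the scatter). Compound 4 is estimated to give 28%, within a range of 10% to 55%.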

Compound 4, a percentage reported as inhibition, at one concentration (the size of the read-out at that concentration, not a potency): 20.6%
Estimate against measurement, compound 4: 7.4 percentage points above; measured number inside the range.
By their numbers in this assay, from the lowest: compounds 4 and 1 (each within the scatter of the next); then compounds 2 and 3 (each within the scatter of the next).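

Compound 4 shows that the low reading in this assay is not particular to pyridin-3-yl: the step of a number 3.9 percentage points lower from compound 1 to compound 4 (within the scatter) lies within the scatter, so moving to pyridin-4-yl on this carbonyl carbon gives no readable change. Going by these compounds alone, the steps of a number 47 percentage points lower from compound 3 to compound 4 (beyond the scatter) and a number 46.9 percentage points lower from compound 2 to compound 4 (beyond the scatter) are both large, and across these four compounds the two pyridine rings read low while 4-isopropylphenyl and cyclopentyl read high, with no compound going against that split. Nothing available explains why these groups divide in this way.

The compounds shown leave open whether the low readings go with the ring nitrogen itself or with the absence of a larger carbon group, since pyridin-4-yl differs from 4-isopropylphenyl in both respects. A plain phenyl ring on the same carbonyl carbon would help separate those two readings, while pyridin-2-yl would test whether the split holds for the remaining placement of the ring nitrogen.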